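The compounds below may be only part of what the source reports. "The series", "measured", "known", "first", "only" and "open" are said of these compounds alone.

Measured in a functional assay on SK-OV-3 cells (Homo sapiens) for antiproliferative activity, read by MTT assay, with a stated time of 72 h; on this read-out higher numbers stand for weaker inhibition and lower numbers for stronger inhibition:
Compound 1 `O=C(CCc1cccc2c1B(O)OC2)Nc1nccs1`: > 100000 nM
Compound 2 `CC(C)(C)OC(=O)Nc1ccc(NC(=O)CCc2cccc3c2B(O)OC3)cc1`: > 100000 nM
Compound 3 `CCOC(=O)c1ccc(NC(=O)CCc2cccc3c2B(O)OC3)cc1`: > 100000 nM

All three entries are limits, not numbers. Compound 1 therefore has no numerical position, and the same holds for the other two: the limit of > 100000 nM in this assay, at which 3 of the 3 values shown sit.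

Compound 4 `O=C(CCc1cccc2c1B(O)OC2)Nc1cccc(I)c1` differs from compound 1 as follows: 3-iodophenyl in place of 1,3-thiazol-2-yl on an amide-type nitrogen. This places 3-iodophenyl in place of 1,3-thiazol-2-yl on an amide-type nitrogen.

Going by the values given here, only one measured step is available, a step that the two limits leave unreadable from compound 2 to compound 3, and it gives no size to carry over. More relevant is that compound 3 also has a six-membered aromatic ring of carbon only on the amide-type nitrogen, and compound 3 still reads > 100000 nM, which is a limit. No step beyond the scatter is therefore expected in this assay, although the data cannot rule one out. The expected change is a number no higher from compound 1 to compound 4 (the limit leaves the size open). The estimate for compound 4 is 100000 nM, with an expected range from 30000 nM to 300000 nM.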

Compound 4, half-maximal inhibitory concentration: 630 nM
Estimate against measurement, compound 4: 160-fold (2.20 log units) above; the measured number lies below the stated range.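

In this assay, exchanging the group on the amide-type nitrogen gives an at least 150-fold lower number from compound 1 to compound 4 (2.20 log units; beyond the scatter), so a change at this position can bring the series from the limit of the assay to a readable number. Compound 3 also carries a six-membered aromatic ring of carbon only on the amide-type nitrogen, and its > 100000 nM is a limit. A ring of this kind is therefore not enough on its own, with compound 2 and compound 3 standing against any such rule, and among the compounds shown only the 3-iodophenyl group of compound 4 gives a readable value.

Going by these compounds, what a plain phenyl, or a chlorine or bromine in place of the iodine, would read remains open. How far the other groups lie from compound 4 also stays unknown, as the comparison rests on one readable number: the limit of > 100000 nM in this assay, at which 3 of the 4 values shown sit.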